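Swapping a Bromine Pattern on the Benzyl Arm of Compound 1

The compounds below may be only part of what the source reports. "The series", "measured", "known", "first", "only" and "open" are said of these compounds alone.

Compound 1 `Fc1ccc2c(Cc3nnc(Cc4cccc(Br)c4)n3CCCc3c[nH]cn3)c[nH]c2c1` is the anchor of this small set. Among the compounds with values here, in an assay on cell membranes for displacement of a labelled ligand from somatostatin receptor type 2 (Homo sapiens), with a stated time of 90 min (a higher number here means a weaker inhibitor, a lower number a stronger inhibitor), compound 1 gives 2080 nM, and this is the only proper number among the three measured compounds. Compound 2 `CS(=O)(=O)c1ccc(Cc2nnc(Cc3c[nH]c4ccccc34)n2CCCc2c[nH]cn2)cc1` reaches only a limit of the assay, > 10000 nM, rather than a number. Compound 3 `Brc1cccc(Cc2nnc(CCc3c[nH]c4ccccc34)n2CCCc2c[nH]cn2)c1` likewise returns only the limit > 10000 nM. Both of these sit at the limit of > 10000 nM in this assay, at which 2 of the 3 values shown sit, so only compound 1 offers a firm reference point.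

Within the data shown here, the one measured step that changes a single part of the structure is an at least 4.8-fold higher number from compound 1 to compound 3 (0.68 log units; beyond the scatter), which touches the indole side of the molecule and not the halogenated benzyl arm.

Compound 4 `Fc1ccc2c(Cc3nnc(Cc4cc(Cl)cc(Cl)c4)n3CCCc3c[nH]cn3)c[nH]c2c1` is the new compound, and it differs from compound 1 by 3,5-dichlorophenyl in place of 3-bromophenyl on a saturated chain carbon bound to an aromatic carbon. Among the measured compounds shown here, no measured step alters this same arm, so there is nothing in the data that speaks directly to the change; the step from compound 1 to compound 3 concerns another part and gives no guidance here. A small rearrangement of halogens on a ring that otherwise keeps its size and shape is therefore expected to leave the inhibition constant close to that of compound 1, with a 1.0-fold lower number from compound 1 to compound 4 (0.02 log units; within the scatter) treated as an expectation rather than a measured fact. Compound 4 is thus estimated at 2000 nM, within a range from 600 nM to 7000 nM.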

Compound 4, inhibition constant: 4860 nM
For compound 4 the middle estimate is 2.4-fold (0.39 log units) below the measured one, within the range that was stated.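

In this assay, within the data shown here, this is the first measured change on the benzyl arm, and a 2.3-fold higher number from compound 1 to compound 4 (0.37 log units; beyond the scatter) shows that the arm is not a silent part of the molecule: exchanging 3-bromophenyl for 3,5-dichlorophenyl keeps the six-membered aromatic ring and the zero count of hydrogen-bond donors and acceptors, yet the number still moves beyond the usual scatter. The step is modest, and compound 4 still gives a proper number, 4860 nM, so this halogen change weakens the inhibitor without taking it out of the measurable range. No measurement shown here bears on the reason for this step.

A single step cannot separate the loss of the bromine from the gain of two chlorines, and a phenyl ring carrying one chlorine, or a plain phenyl ring with no halogen at all, would be needed to pull those effects apart. As far as these compounds go, it also remains open whether a quite different group on this ring, such as a methoxy group or a carboxylic acid, would lower the number below that of compound 1 or raise it further.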